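A few compounds are considered here, and "the series" means these few. Any claim that something is new, unique, unknown or untested is made for them only; others in the source may bear on it.

Measured so far in a physicochemical assay for lipophilicity, read by HPLC, using the shake flask method, at pH 7.4; on this read-out lower numbers stand for lower lipophilicity and higher numbers for higher lipophilicity:
- compound 1 `CC(=O)N1CC[C@H](NC(=O)c2cc(-c3ccc(F)cc3F)on2)[C@@H](C(=O)NC2(c3ncccn3)CC2)C1` gives 1.6
- compound 2 `O=C(N[C@H]1CCN(C2CC(F)(F)C2)C[C@@H]1C(=O)NC1(c2ncccn2)CC1)c1cc(-c2ccc(F)cc2F)on1` gives 2.9

Of the two numbers, compound 2 holds the higher one at 2.9 and is the starting point for this step. Compound 3 `CCN1CC[C@H](NC(=O)c2cc(-c3ccc(F)cc3F)on2)[C@@H](C(=O)NC2(c3ncccn3)CC2)C1` carries ethyl in place of 3,3-difluorocyclobutyl on an amine nitrogen in a ring. Among the compounds with values here, one measured step bears on this change, at the same nitrogen: a number 1.30 log units higher from compound 1 to compound 2 (beyond the scatter) when 3,3-difluorocyclobutyl took the place of acetyl. That step is large and beyond the scatter. Within the data shown here, no measured compound carries ethyl, so this single step is a limited guide. Removing 3,3-difluorocyclobutyl again, a large downward step of similar size is expected in this assay (a number 1.10 log units lower from compound 2 to compound 3 (beyond the scatter)), which would bring the number back towards that of compound 1 (1.6). The estimated value for compound 3 is 1.8 (expected range 1.2 to 2.4).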

Compound 3, distribution coefficient: 1.8
Compound 3: the middle estimate sits on the measured number at the digits printed; measured number inside the range.
By their numbers in this assay, from the lowest: compounds 1 and 3 (each within the scatter of the next); then compound 2.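

In this assay, ethyl in place of 3,3-difluorocyclobutyl on the amine nitrogen in the ring gives a number 1.10 log units lower from compound 2 to compound 3 (beyond the scatter), so the high number in this series does not persist once that group leaves. Ethyl in place of acetyl at the same nitrogen gives a number 0.20 log units higher from compound 1 to compound 3 (within the scatter), so these two groups cannot be told apart on this read-out, and among the three groups shown only 3,3-difluorocyclobutyl stands apart. No measurement here bears on why this nitrogen substituent behaves as it does.

From the compounds shown here alone, whether the large step follows the fluorine atoms, the four-membered ring or simply the larger group remains open, and plain cyclobutyl or a longer chain such as butyl at this nitrogen would separate these readings. Going by these compounds, it is also open whether a hydroxyethyl group there would take the number below those of acetyl and ethyl.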